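From benzylsulfanyl to 3-chlorophenyl on the shared core

This account rests on a few compounds, and the source may have more. Where it says the series, first, only, none or still open, it means among the compounds named here.

Three analogues of one core have been measured in an assay on CHO cells for antagonist activity at transient receptor potential cation channel subfamily V member 1 (Homo sapiens), read by FLIPR; a lower number here means a stronger inhibitor, a higher number a weaker inhibitor. Compound 1 `CC(C(=O)NCc1ccc(C(F)(F)F)cc1N1CCN(c2ccccc2)CC1)c1ccc(NS(C)(=O)=O)c(F)c1` gives 2 nM; compound 2 `CC(C(=O)NCc1ccc(C(F)(F)F)cc1OCc1ccc(F)cc1)c1ccc(NS(C)(=O)=O)c(F)c1` gives 0.5 nM; compound 3 `CC(C(=O)NCc1ccc(C(F)(F)F)cc1SCc1ccccc1)c1ccc(NS(C)(=O)=O)c(F)c1` gives 0.5 nM. Compound 3 thus sits level with compound 2, the two together at the lowest numbers, while a 4.0-fold lower number from compound 1 to compound 3 (0.60 log units; beyond the scatter) marks its distance from compound 1. Compound 4 `CC(C(=O)NCc1ccc(C(F)(F)F)cc1-c1cccc(Cl)c1)c1ccc(NS(C)(=O)=O)c(F)c1` differs from compound 3 in one place: 3-chlorophenyl in place of benzylsulfanyl on an aromatic carbon. For the measured compounds named here, no measured step involves 3-chlorophenyl, so only the general behaviour of this position can guide the expectation: no change at the digits printed from compound 2 to compound 3 (within the scatter) and a 4.0-fold lower number from compound 1 to compound 3 (0.60 log units; beyond the scatter) show that exchanges here range from no change to a modest shift. A modest rise in this assay is therefore expected for compound 4, namely a 2.0-fold higher number from compound 3 to compound 4 (0.30 log units; within the scatter). Compound 4 is estimated at 1 nM, between 0.3 nM and 4 nM.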

Compound 4, inhibition constant: 1 nM
Compound 4: middle estimate and measured number agree at the digits printed; measured number inside the range.
By their numbers in this assay, from the lowest: compounds 2, 3, 4 and 1 (each within the scatter of the next, the first and the last beyond it).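

In this assay this position also accepts 3-chlorophenyl, a ring with no sulfur or oxygen in the group: exchanging benzylsulfanyl gives a small step (a 2.0-fold higher number from compound 3 to compound 4 (0.30 log units; within the scatter)), and exchanging (4-fluorobenzyl)oxy gives the same (a 2.0-fold higher number from compound 2 to compound 4 (0.30 log units; within the scatter)). Exchanging 4-phenylpiperazin-1-yl also stays within the scatter (a 2.0-fold lower number from compound 1 to compound 4 (0.30 log units; within the scatter)), so compound 4 lies within the scatter of all three earlier compounds, although compound 1 lies beyond it from compounds 2 and 3. Nothing at hand explains these numbers.

The compounds shown leave open what the chlorine of 3-chlorophenyl contributes. They also leave open whether an amine or a carboxylic acid at this position would keep the number in this range.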